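A few compounds are considered here, and "the series" means these few. Any claim that something is new, unique, unknown or untested is made for them only; others in the source may bear on it.

Measured so far in a functional assay on cells (KATO III cell, Homo sapiens) for antiproliferative activity, read by MTT assay; on this read-out higher numbers stand for weaker inhibition and lower numbers for stronger inhibition:
- Compound 1 `O=C1NC(c2ccccc2)CN1S(=O)(=O)c1ccc2c(c1)CCCN2` gives > 20000 nM (a limit of the assay, not a number)
- Compound 2 `CC(C)COC(=O)N1CCCc2cc(S(=O)(=O)N3CC(c4ccccc4)NC3=O)ccc21` gives 2750 nM
- Compound 3 `C=CCOC(=O)N1CCCc2cc(S(=O)(=O)N3CC(c4ccccc4)NC3=O)ccc21` gives 5050 nM

Within the data shown here, compound 2 and compound 3 are the only two with actual numbers, and they lie within the scatter of each other: a 1.8-fold higher number from compound 2 to compound 3 (0.26 log units; within the scatter). Compound 4 `O=C(c1ccccc1)N1CCCc2cc(S(=O)(=O)N3CC(c4ccccc4)NC3=O)ccc21` has not yet been measured. It has phenyl in place of isobutoxy on a carbonyl carbon, so that isobutoxycarbonyl gives way to benzoyl: phenyl in place of isobutoxy on a carbonyl carbon.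

Two steps show that a carbonyl-bearing group matters, an at least 7.2-fold lower number from compound 1 to compound 2 (0.86 log units; beyond the scatter) and an at least 3.9-fold lower number from compound 1 to compound 3 (0.59 log units; beyond the scatter). Compound 4 keeps the carbonyl. Among the measured compounds shown here, the one change made further out on that group, from compound 2 to compound 3, stayed within the scatter at a 1.8-fold higher number from compound 2 to compound 3 (0.26 log units; within the scatter). For the measured compounds named here, no measured compound carries benzoyl, however, so this comparison is only a loose guide.

No step beyond the scatter is therefore expected, and the estimate is a 1.1-fold higher number from compound 2 to compound 4 (0.04 log units; within the scatter). Compound 4 is expected at about 3000 nM, with an estimated range from 800 nM to 11000 nM.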

Compound 4, half-maximal inhibitory concentration: 14300 nM
For compound 4 the middle estimate is 4.8-fold (0.68 log units) below the measured one; measured number above the stated range.
By their numbers in this assay, from the lowest: compounds 2 and 3 (each within the scatter of the next); then compound 4. At a limit, above all of these: compound 1.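

In this assay, among these compounds, this is the first change on the carbonyl carbon that goes beyond the scatter: a 5.2-fold higher number from compound 2 to compound 4 (0.72 log units; beyond the scatter), and a 2.8-fold higher number from compound 3 to compound 4 (0.45 log units; beyond the scatter). A carbonyl on the ring nitrogen is therefore not enough on its own, and what is attached to that carbonyl also counts, with isobutoxy and allyloxy both giving lower numbers than phenyl. Benzoyl in place of hydrogen on that nitrogen gives only a floor for the step: an at least 1.3-fold lower number from compound 1 to compound 4 (0.14 log units; that floor lies within the scatter). Compound 1 stands at a limit of the assay rather than a number: the limit of > 20000 nM in this assay, at which 1 of the 4 values shown sits.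

The compounds shown leave open whether the rise in compound 4 goes with losing the oxygen on the carbonyl carbon or with gaining the aromatic ring. Benzyloxycarbonyl, which holds both that oxygen and a phenyl ring, and acetyl, which holds neither, would help to tell these apart.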